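Swapping a dimethylphenyl for a trifluorophenyl on the amide

A few compounds are considered here, and "the series" means these few. Any claim that something is new, unique, unknown or untested is made for them only; others in the source may bear on it.

Two compounds share a malonate-derived core that links an ester oxygen to a 2,6-diisopropylphenyl group and an amide nitrogen to a second aromatic ring. Compound 1 `Cc1cccc(C)c1NC(=O)CC(=O)Oc1c(C(C)C)cccc1C(C)C` carries a 2,6-dimethylphenyl on that nitrogen; in an assay on microsomes from intestine for inhibition of acyl-CoA:cholesterol acyltransferase (Oryctolagus cuniculus) (a higher number here means a weaker inhibitor, a lower number a stronger inhibitor), compound 1 gives 210 nM. Compound 2 `CCCCCCCCCCC(C)OC(=O)CC(=O)Nc1c(C(C)C)cccc1C(C)C`, whose aromatic rings are placed the other way round and which carries a long branched chain on the ester side, gives 6 nM in this assay. Compound 1 therefore has the highest number of the two, and the gap to compound 2 lies beyond the scatter.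

Compound 3 `CC(C)c1cccc(C(C)C)c1OC(=O)CC(=O)Nc1c(F)cc(F)cc1F` keeps the core of compound 1 and introduces (2,4,6-trifluorophenyl in place of 2,6-dimethylphenyl on an amide-type nitrogen). For the measured compounds named here, no measured pair shows this change directly, so any expectation rests on compound 1 alone. A modest rise in the number is expected, a step from a 2.9-fold higher number from compound 1 to compound 3 (0.46 log units; beyond the scatter) that may reach beyond the scatter. Compound 3 is estimated at 600 nM, with a range from 150 nM to 3000 nM.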

Compound 3, half-maximal inhibitory concentration: > 5000 nM
Compound 3: no number, only a limit; the forecaster's own chance of this, stated with the estimate: 10%; middle value at least 8.3-fold (0.92 log units) from the limit.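

In this assay compound 3 gives > 5000 nM, which is a limit of the assay and not a number. Putting 2,4,6-trifluorophenyl in place of 2,6-dimethylphenyl on the amide-type nitrogen, with the rest of the core of compound 1 unchanged, gives an at least 23-fold higher number from compound 1 to compound 3 (1.37 log units; beyond the scatter), so inhibition here depends strongly on what this ring carries. The true size of the step remains unknown, since it rests on a limit: the limit of > 5000 nM in this assay, at which 1 of the 3 values shown sits.

The compounds shown do not separate the departure of the two methyl groups from the arrival of the three fluorines. As far as these compounds go, it also remains open how this ring would fare with a chlorine or a methoxy group in place of those fluorines.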